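The source may hold more compounds than are shown below. What is called first, only, known or untested is meant among the compounds shown, and "the series" means these compounds.

Measured so far:
- compound 1 `CCCCNC(=O)N1CC1C#N`: 17000 nM
- compound 2 `N#CC1CN1C(=O)Nc1ccc(F)cc1`: 5900 nM

In a functional assay on RPMI-8226 cells (Homo sapiens) for inhibition (on this read-out lower numbers stand for stronger inhibition and higher numbers for weaker inhibition), compound 2 gives 5900 nM and so stands at the lowest of the two numbers; compound 1, the nearest, gives 17000 nM, a gap beyond the scatter. Compound 3 `CCOC(=O)c1ccc(NC(=O)N2CC2C#N)cc1` is not yet measured. It differs from compound 2 by ethoxycarbonyl in place of fluoro on an aromatic carbon. Within the data shown here, no step between measured compounds covers such a change, so the size is open; on two data points only, a small step is expected, if anything toward a lower number. For compound 3 the estimated half-maximal inhibitory concentration is 4000 nM (range 1000 nM to 16000 nM), an expected step of a 1.5-fold lower number from compound 2 to compound 3 (0.17 log units; within the scatter).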

Compound 3, half-maximal inhibitory concentration: 3000 nM
Estimate against measurement, compound 3: 1.3-fold (0.12 log units) above; low and high end bracket the measured number.
By their numbers in this assay, from the lowest: compounds 3 and 2 (each within the scatter of the next); then compound 1.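

Ethoxycarbonyl in place of fluoro on the aromatic carbon gives a 2.0-fold lower number from compound 2 to compound 3 (0.29 log units; within the scatter) in this assay, so this position accepts the larger ester group with no step beyond the scatter. With one step at this position, the read-out shows no clear sensitivity to this change. No measurement here bears on the reason for this result.

Open, going by these compounds, is how an amine or a carboxylic acid on the same aromatic carbon would read. Also open, on these data alone, is whether a longer chain on the ester would stay within the scatter of compound 3.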